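Methoxy substitution on the anilino ring of sulfonylquinoxalines

The source may hold more compounds than are shown below. What is called first, only, known or untested is meant among the compounds shown, and "the series" means these compounds.

Measured compounds:
Compound 1, `COc1cc(Nc2nc3ccccc3nc2S(=O)(=O)c2ccc(C)cc2)cc(OC)c1`: 2940 nM
Compound 2, `COc1cc(Nc2nc3ccccc3nc2S(=O)(=O)c2ccc(C)cc2)cc(OC)c1OC`: 4850 nM
Compound 3, `COc1ccc(S(=O)(=O)c2nc3ccccc3nc2Nc2ccccc2)cc1`: 1260 nM

All three were tested in a functional assay on PC-3 cells (Homo sapiens) for cytotoxicity, read by MTT assay, with a stated time of 72 h; on this read-out higher numbers stand for weaker inhibition and lower numbers for stronger inhibition. Compound 1 gives 2940 nM and compound 2 gives 4850 nM; the step of a 1.6-fold higher number from compound 1 to compound 2 (0.22 log units; within the scatter) is the change (methoxy in place of hydrogen on an aromatic carbon). Compound 3 gives 1260 nM, the lowest of the three numbers; its gap to compound 1 and to compound 2 is beyond the scatter in each case. The difference between the core of compound 3 and that of compound 1 is not broken down here.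

Compound 4, `COc1ccc(Nc2nc3ccccc3nc2S(=O)(=O)c2ccc(OC)cc2)cc1`, is not yet measured. It differs from compound 3 by methoxy in place of hydrogen on an aromatic carbon. This is the same kind of change as from compound 1 to compound 2, but not the same: in compound 2 the entering methoxy sits ortho to two methoxy groups and para to a large group, whereas in compound 4 it sits only para to a large group, with no methoxy neighbours. Within the data shown here, the one measured instance of this change, a 1.6-fold higher number from compound 1 to compound 2 (0.22 log units; within the scatter), stayed within the scatter, so a small step is expected here too, leaning toward a somewhat higher number because of a 1.6-fold higher number from compound 1 to compound 2 (0.22 log units; within the scatter). For compound 4 the expected step is a 1.4-fold higher number from compound 3 to compound 4 (0.15 log units; within the scatter). Compound 4 is thus estimated at 1800 nM, with a range of 800 nM to 4500 nM.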

Compound 4, half-maximal inhibitory concentration: 8710 nM
Beside the measured number, compound 4's estimate is 4.8-fold (0.68 log units) below it, outside the stated range (above it).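

In this assay, methoxy in place of hydrogen on an aromatic carbon does not carry over from one core to the other with one size of step: the same change on two cores in this assay, a 1.6-fold higher number (0.22 log units; within the scatter) from compound 1 to compound 2 and a 6.9-fold higher number (0.84 log units; beyond the scatter) from compound 3 to compound 4, 4.2-fold (0.62 log units) apart, beyond the scatter of two such steps

The new step, a 6.9-fold higher number from compound 3 to compound 4 (0.84 log units; beyond the scatter), lies beyond the scatter, whereas a 1.6-fold higher number from compound 1 to compound 2 (0.22 log units; within the scatter) stays within it, so a step read on the core of compound 1 gave no reliable measure of the size of the step on the core of compound 3, although both numbers moved in the same direction, toward weaker inhibition. Among these compounds, with only two steps, this does not show which structural difference sets them apart, since the cores differ in more than one place and the ring taking the methoxy already carries methoxy groups in compound 1 but none in compound 3.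

Still open, on these data alone, is whether the rise from compound 3 belongs to methoxy itself, or whether hydroxy, fluorine, ethoxy or an amine in the same place on the anilino ring would give a similar number. Also open, as far as these compounds go, is how the step would behave on a third core, and whether the contrast between these two steps would hold there.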